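Swapping Bromo for Methoxy in a Series Stuck at the Limit

A few compounds are considered here, and "the series" means these few. Any claim that something is new, unique, unknown or untested is made for them only; others in the source may bear on it.

Three compounds share one core and differ only in the aryl group on the nitrogen on an aromatic ring. Compound 1 `COc1cc2ncnc(Nc3cccc(F)c3)c2cc1OCCCCC(=O)Nc1ccc(S(N)(=O)=O)cc1` carries a 3-fluorophenyl there. In a functional assay on A549 cells (Homo sapiens) for antiproliferative activity, read by MTT assay, with a stated time of 72 h (on this read-out lower numbers stand for stronger inhibition and higher numbers for weaker inhibition), compound 1 gives only a limit of the assay, > 40000 nM. Compound 2 `COc1cc2ncnc(Nc3ccc(Cl)cc3)c2cc1OCCCCC(=O)Nc1ccc(S(N)(=O)=O)cc1` carries a 4-chlorophenyl, and in this assay compound 2 likewise reaches only a limit, > 40000 nM. Compound 3 `COc1cc2ncnc(Nc3ccc(Br)cc3)c2cc1OCCCCC(=O)Nc1ccc(S(N)(=O)=O)cc1` carries a 4-bromophenyl, and in this assay compound 3 again gives only a limit, > 40000 nM. Because (the limit of > 40000 nM in this assay, at which 3 of the 3 values shown sit), none of the three steps between these compounds can be sized: a step that the two limits leave unreadable from compound 1 to compound 2, a step that the two limits leave unreadable from compound 1 to compound 3 and a step that the two limits leave unreadable from compound 2 to compound 3 are all unreadable. Compound 3 therefore stands at the limit of the assay, with no number of its own.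

Compound 4 `COc1ccc(Nc2ncnc3cc(OC)c(OCCCCC(=O)Nc4ccc(S(N)(=O)=O)cc4)cc23)cc1` differs from compound 3 in one place: methoxy in place of bromo on an aromatic carbon. For the measured compounds named here, no measured step resembles this change, and the three measured steps are unreadable, so neither a direction nor a size can be taken from them. Compound 4 is expected to stay at or near the limit, so the expected step of a number no higher from compound 3 to compound 4 (the limit leaves the size open) is one that cannot be read. The estimate for compound 4 in this assay is 40000 nM, within 10000 nM to 100000 nM.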

Compound 4, half-maximal inhibitory concentration: > 40000 nM
Compound 4 ended at the assay's limit (the forecaster's own chance of this, stated with the estimate: 70%); the middle value sits exactly at the limit.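

In this assay compound 4 gives > 40000 nM, a limit and not a number. The steps to compound 4 from compound 1, compound 2 and compound 3 cannot be read, because every value rests at the same limit: the limit of > 40000 nM in this assay, at which 4 of the 4 values shown sit.

The compounds shown leave open how strong each one is and whether changing the aryl group alters activity at all.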